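Methoxy added to a bromobenzamide that shows no inhibition

The compounds below may be only part of what the source reports. "The series", "measured", "known", "first", "only" and "open" are said of these compounds alone.

Measured compounds:
compound 1, `O=C(Nc1cccc(Cl)c1)c1cc(Br)cc(Br)c1`, > 100000 nM
compound 2, `O=C(Nc1ccc(Sc2nc3ccccc3s2)c(Cl)c1)c1cccc(Br)c1`, > 100000 nM
compound 3, `O=C(Nc1ccc(Sc2nc3ccccc3s2)cc1)c1cccc(Br)c1`, > 100000 nM

Compound 2, `O=C(Nc1ccc(Sc2nc3ccccc3s2)c(Cl)c1)c1cccc(Br)c1`, stands at a limit of the assay rather than at a number: in an assay on isolated protein for inhibition of thiosulfate sulfurtransferase (Homo sapiens), with a stated time of 60 min, in the absence of a further agent (a lower number here means a stronger inhibitor, a higher number a weaker inhibitor), compound 2 gives > 100000 nM. Compound 1, `O=C(Nc1cccc(Cl)c1)c1cc(Br)cc(Br)c1`, also gives only a limit there, > 100000 nM. Compound 3, `O=C(Nc1ccc(Sc2nc3ccccc3s2)cc1)c1cccc(Br)c1`, likewise gives a limit, > 100000 nM. Among the compounds with values here, all three sit at the limit of > 100000 nM in this assay, at which 3 of the 3 values shown sit, so no measured step within this set can be read; the step that the two limits leave unreadable from compound 2 to compound 3 stays unreadable.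

Compound 4, `COc1ccc(Br)cc1C(=O)Nc1ccc(Sc2nc3ccccc3s2)c(Cl)c1`, differs from compound 2 by methoxy in place of hydrogen on an aromatic carbon. Within the data shown here, no measured pair shows the effect of a methoxy group entering in this way, and every value here is a limit, so there is no readable step to set an expectation against. With compound 2 at a limit, compound 4 is expected to remain at or beyond that limit, and the step that the limit leaves unreadable from compound 2 to compound 4 is expected to be no more than scatter. Compound 4 is therefore estimated at 200000 nM, between 50000 nM and 1000000 nM.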

Compound 4, half-maximal inhibitory concentration: > 100000 nM
Compound 4 was reported as a limit; the forecaster's own chance of this, stated with the estimate: 80%; the middle value does not contradict the limit.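

Compound 4, like compound 2, gives only a limit and not a number, so no step between the two can be read: the limit of > 100000 nM in this assay, at which 4 of the 4 values shown sit.

The compounds shown leave open whether any close relative gives a measured value in this assay, and so what methoxy in this place does to inhibition.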